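A few compounds are considered here, and "the series" means these few. Any claim that something is new, unique, unknown or untested is made for them only; others in the source may bear on it.

Compound 1 `CC(=O)N1N=C(c2ccc(-n3nc(C)n(N)c3=O)cc2)CC1c1ccc(O)cc1` was tested in an assay on isolated protein for inhibition of pancreatic alpha-amylase (Homo sapiens), with a stated time of 10 min, tested at 1 mg/mL (on this read-out lower numbers stand for less inhibition and higher numbers for more inhibition at the one concentration tested (going by the name of the read-out)), and gave 76.7%, level with compound 3 `CC(=O)N1N=C(c2ccc(-n3nc(C)n(N)c3=O)cc2)CC1c1ccccc1Cl`, which gave 76.7%; together they stand lowest of the three numbers, while compound 2 `COc1ccc(C2CC(c3ccc(-n4nc(C)n(N)c4=O)cc3)=NN2C(C)=O)cc1` gave 96.5%. The measured steps are a number 19.8 percentage points higher from compound 1 to compound 2 (beyond the scatter), no change at the digits printed from compound 1 to compound 3 (within the scatter) and a number 19.8 percentage points lower from compound 2 to compound 3 (beyond the scatter). Compound 4 `CC(=O)N1N=C(c2ccc(-n3nc(C)n(N)c3=O)cc2)CC1c1cccc(Cl)c1` differs from compound 1 in this way: 3-chlorophenyl in place of 4-hydroxyphenyl on a saturated ring carbon. The step that bears on it most is no change at the digits printed from compound 1 to compound 3 (within the scatter), since there too a chlorophenyl replaced the 4-hydroxyphenyl on the saturated ring carbon; no change beyond the scatter is therefore expected in this assay. The expected step is a number 1.3 percentage points higher from compound 1 to compound 4 (within the scatter). Compound 4 is thus estimated at 78%, in a range from 65% to 90%.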

Compound 4, a percentage reported as inhibition, at one concentration (the size of the read-out at that concentration, not a potency): 96.5%
Beside the measured number, compound 4's estimate is 18.5 percentage points below it, and the stated range ends below it.
By their numbers in this assay, from the lowest: compounds 1 and 3 (each within the scatter of the next); then compounds 2 and 4 (each within the scatter of the next).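

In this assay the place of the chlorine on the aromatic ring matters at this saturated ring carbon, with a number 19.8 percentage points higher from compound 3 to compound 4 (beyond the scatter) for 3-chlorophenyl in place of 2-chlorophenyl. A chlorophenyl group in place of 4-hydroxyphenyl therefore does not always leave the number unchanged, as a number 19.8 percentage points higher from compound 1 to compound 4 (beyond the scatter) shows. The 3-chlorophenyl group instead sits level with 4-methoxyphenyl, with no change at the digits printed from compound 2 to compound 4 (within the scatter) for that swap. Going by these compounds, how 4-chlorophenyl, or an aromatic ring carrying an amine or a carboxylic acid, would read at this carbon stays open. No evidence here explains why the two chlorophenyl groups differ.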